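Exchanging the Dibromophenyl Sulfonamide for a Tolyl Group

This account rests on a few compounds, and the source may have more. Where it says the series, first, only, none or still open, it means among the compounds named here.

Compound 1 `COc1cc(N)c(Cl)cc1C(=O)CCC1CCN(CCNS(=O)(=O)c2cc(Br)ccc2Br)CC1` was tested in an assay on brain for displacement of a labelled ligand from 5-hydroxytryptamine receptor 4 (Cavia porcellus), with a stated time of 30 min, in the presence of a further agent that is not named here (on this read-out lower numbers stand for stronger inhibition and higher numbers for weaker inhibition), and gave 16.3 nM. Among the two compounds with a number, compound 1 stands highest. Its nearest neighbour is compound 2 `COc1cc(N)c(Cl)cc1C(=O)CCC1CCN(CCNS(=O)(=O)c2ccc3c(c2)NC(=O)CO3)CC1`, in which a different aryl group sits on the sulfonyl sulfur; in this assay compound 2 gives 6.2 nM, a step of a 2.6-fold lower number from compound 1 to compound 2 (0.42 log units; beyond the scatter). A third compound, compound 3 `COc1ccc(S(=O)(=O)N2CCC(CCC(=O)c3cc(Cl)c(N)cc3OC)CC2)cc1`, carries its sulfonyl group directly on the piperidine nitrogen rather than through an aminoethyl linker; its result in this assay is "not determined" (no result reported), so it adds nothing to the comparison.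

Compound 4 `COc1cc(N)c(Cl)cc1C(=O)CCC1CCN(CCNS(=O)(=O)c2ccc(C)cc2)CC1` differs from compound 1 in one place: 4-methylphenyl in place of 2,5-dibromophenyl on a sulfonyl sulfur. For the measured compounds named here, the only measured step that bears on this position is the one from compound 1 to compound 2, where a change of the aryl group on the sulfonyl sulfur produced a modest lowering of the number. That step concerns a different replacement, so it sets only a loose expectation that the aryl group here is tolerated and that changes at this position stay modest. Compound 4 is therefore expected to show a change of about a 1.4-fold lower number from compound 1 to compound 4 (0.13 log units; within the scatter), most likely within or only slightly beyond the scatter. The estimate for compound 4 in this assay is 12 nM, with a range from 4 nM to 40 nM.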

Compound 4, inhibition constant: 18 nM
Compound 4: the middle estimate sits 1.5-fold (0.18 log units) below what was measured; low and high end bracket the measured number.
By their numbers in this assay, from the lowest: compound 2; then compounds 1 and 4 (each within the scatter of the next).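

In this assay, the exchange of 2,5-dibromophenyl for 4-methylphenyl on the sulfonyl sulfur gives a 1.1-fold higher number from compound 1 to compound 4 (0.04 log units; within the scatter), so the bromine atoms can give way to a methyl group with no change that can be told from the scatter. The other step at this position, a 2.9-fold higher number from compound 2 to compound 4 (0.46 log units; beyond the scatter), means that compound 2 now stands apart from two simple substituted phenyl groups rather than from one, and among these compounds the lower number goes with the group of compound 2 alone, the one that carries a six-membered non-aromatic ring with hetero atoms. Nothing at hand explains why these aryl groups fall as they do.

The compounds shown leave open whether the amide within the group of compound 2 goes with its lower number, and whether an unsubstituted phenyl, a 4-methoxyphenyl or a pyridine ring on the sulfonyl sulfur would fall with compound 1 and compound 4 or with compound 2. They also leave open how a longer chain in place of the aminoethyl linker would fare with any of these aryl groups.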